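This account rests on a few compounds, and the source may have more. Where it says the series, first, only, none or still open, it means among the compounds named here.

Measured values in a functional assay on MCF7 cells (Homo sapiens) for antiproliferative activity, read by MTT assay, with a stated time of 24 h (on this read-out lower numbers stand for stronger inhibition and higher numbers for weaker inhibition), are these:
Compound 1 `CCn1c(C(=O)N[C@@H](CC(=O)OC)C(=O)OC)ccc1C(CC)(CC)c1ccc(OCS(=O)(=O)c2ccccc2)c(C)c1` gives > 50000 nM (a limit of the assay, not a number)
Compound 2 `CCn1c(C(=O)N[C@@H](C)C(=O)O)ccc1C(CC)(CC)c1ccc(OCS(=O)(=O)c2ccccc2)c(C)c1` gives 35500 nM
Compound 3 `CCn1c(C(=O)NCC(=O)O)ccc1C(CC)(CC)c1ccc(OCS(=O)(=O)c2ccccc2)c(C)c1` gives 33100 nM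

Compound 3 stands level with compound 2 on these numbers, and the gap between them is a 1.1-fold lower number from compound 2 to compound 3 (0.03 log units; within the scatter). The only other entry, for compound 1, is a limit. The change to compound 4 `CCn1c(C(=O)N[C@@H](CC(=O)O)C(=O)O)ccc1C(CC)(CC)c1ccc(OCS(=O)(=O)c2ccccc2)c(C)c1` is carboxymethyl in place of hydrogen on a saturated chain carbon bound to an amide-type nitrogen and a carbonyl carbon and leaves a 1,2-dicarboxyethyl group on the amide-type nitrogen.

Two kinds of measured step bear on this change. At the same carbon, methyl and hydrogen were compared in a 1.1-fold lower number from compound 2 to compound 3 (0.03 log units; within the scatter), which shows no measurable effect of that swap. Compound 1, which carries 1,2-bis(methoxycarbonyl)ethyl on the amide-type nitrogen, offers only an at least 1.4-fold lower number from compound 1 to compound 2 (0.14 log units; that floor lies within the scatter) and an at least 1.5-fold lower number from compound 1 to compound 3 (0.17 log units; that floor lies within the scatter), and these are floors rather than measured sizes.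

Going by the values given here, no step beyond the scatter is therefore expected in this assay, with any drift expected toward weaker inhibition given compound 1 and the limit of > 50000 nM in this assay, at which 1 of the 3 values shown sits, as the only guide. The expected step is a 1.1-fold higher number from compound 3 to compound 4 (0.06 log units; within the scatter) as estimated here. Compound 4 is estimated at 38000 nM, with an expected range from 20000 nM to 65000 nM.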

Compound 4, half-maximal inhibitory concentration: > 50000 nM
Compound 4: a limit, no number; the forecaster's own chance of this, stated with the estimate: 30%; at least 1.3-fold (0.11 log units) between middle value and limit.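

Against hydrogen at the saturated chain carbon bound to an amide-type nitrogen and a carbonyl carbon, carboxymethyl gives an at least 1.5-fold higher number from compound 3 to compound 4 (0.17 log units; that floor lies within the scatter) in this assay, and the comparison with the methyl analogue gives an at least 1.4-fold higher number from compound 2 to compound 4 (0.14 log units; that floor lies within the scatter); both floors lie within the scatter, so a weakening is not established, but this is the first change at this carbon that leaves the compound without a number. Compound 4, with its 1,2-dicarboxyethyl group, thus shares the end of the read-out with the compound carrying 1,2-bis(methoxycarbonyl)ethyl: the limit of > 50000 nM in this assay, at which 2 of the 4 values shown sit. The step from compound 1 to compound 4 cannot be read, so these data do not separate the diacid from the diester.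

As far as these compounds go, the true size of the steps to compound 4 stays open, as does whether a longer chain ending in a carboxylic acid or an amine at this carbon would return a number. From the compounds shown here alone, it is also open whether an ethyl group there, with no carboxylic acid, would stay level with methyl and hydrogen.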